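Swapping a Branched Chain for a Pyridine Ring

The compounds below may be only part of what the source reports. "The series", "measured", "known", "first", "only" and "open" are said of these compounds alone.

Compound 1 `CNc1nc(NCC(C)(C)C)cc(-c2ccccn2)n1` stands second highest of the three numbers measured in a functional assay on HEK293 cells for agonist activity at G-protein coupled receptor 39 (Homo sapiens), read by inositol phosphate accumulation (a higher number here means that more compound is needed for the effect, a lower number that less compound is needed), where compound 1 gives 73 nM. Compound 2 `CNc1nc(NCc2ccc(S(C)(=O)=O)cc2)cc(-c2ccccn2)n1` gives 36 nM, a lower number that lies beyond the scatter. Compound 3 `CC(C)(C)CNc1nc(NCC2CC2)cc(-c2ccccn2)n1` gives 5000 nM, a far higher number. Compound 4 `CNc1nc(NCc2ccncc2)cc(-c2ccccn2)n1` has not yet been measured; compared with compound 1 it carries pyridin-4-yl in place of tert-butyl on a saturated chain carbon bound to a nitrogen on an aromatic ring. Among the compounds with values here, no measured pair mirrors this exact change, but compound 2 shows that an aromatic ring at that place, carried on the same kind of chain, is compatible with a low number. The step of a 1.5-fold lower number from compound 1 to compound 4 (0.16 log units; within the scatter) is therefore expected to be small and downward, if beyond the scatter at all. For compound 4 the estimate in this assay is 50 nM, with a range from 15 nM to 200 nM.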

Compound 4, half-maximal effective concentration: 87 nM
Beside the measured number, compound 4's estimate is 1.7-fold (0.24 log units) below it; the range from low to high includes it.
By their numbers in this assay, from the lowest: compound 2; then compounds 1 and 4 (each within the scatter of the next); then compound 3.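

In this assay, the step with pyridin-4-yl in place of tert-butyl is a 1.2-fold higher number from compound 1 to compound 4 (0.08 log units; within the scatter), which lies within the scatter. On this saturated chain carbon bound to a nitrogen on an aromatic ring, a branched carbon group and a six-membered aromatic ring with one hetero atom therefore give numbers that cannot be told apart. Nothing available explains this match.

As far as these compounds go, it remains open how pyridin-3-yl or an unsubstituted phenyl ring would read at this place. The same holds for a carboxylic acid or a longer chain.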